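The compounds below may be only part of what the source reports. "The series", "measured", "known", "first", "only" and "open" are said of these compounds alone.

In a functional assay on NUGC-3 cells (Homo sapiens) for antiproliferative activity, read by sulforhodamine B assay (a higher number here means a weaker inhibitor of growth, a lower number a stronger inhibitor of growth), compound 2 `O=C(/C=C/c1ccc(O)cc1)c1c(O)cccc1OCC1CCCC1` gives 2140 nM and compound 1 `CC(C)(C)CCOc1cccc(O)c1C(=O)/C=C/c1ccc(O)cc1` gives 3300 nM. Among the measured compounds shown here, these are the only two numbers so far, and they lie within the usual scatter of each other. For the measured compounds named here, the next molecule, compound 3 `CC(C)CCOc1cccc(O)c1C(=O)/C=C/c1ccc(O)cc1`, keeps the shared core and alters only one group: isobutyl in place of cyclopentyl on a saturated chain carbon bound to an oxygen on an aromatic ring. In words, this is isobutyl in place of cyclopentyl on a saturated chain carbon bound to an oxygen on an aromatic ring. Going by the values given here, one measured step bears on this, the swap at the same place that gave a 1.5-fold lower number from compound 1 to compound 2 (0.19 log units; within the scatter). Among the compounds with values here, with only that small step as a guide, no change beyond the scatter is expected in this assay, and the direction cannot be told with confidence. The expected step is a 1.3-fold higher number from compound 2 to compound 3 (0.12 log units; within the scatter). The estimate for compound 3 is 2800 nM, with an expected range from 1300 nM to 6000 nM.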

Compound 3, concentration for 50% growth inhibition: 12400 nM
For compound 3 the middle estimate is 4.4-fold (0.65 log units) below the measured one; measured number above the stated range.
By their numbers in this assay, from the lowest: compounds 2 and 1 (each within the scatter of the next); then compound 3.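

In this assay, the step of a 5.8-fold higher number from compound 2 to compound 3 (0.76 log units; beyond the scatter) shows that this place, on a saturated chain carbon bound to an oxygen on an aromatic ring, can shift the number beyond the scatter, which the step between compound 1 and compound 2 did not show. The step of a 3.8-fold higher number from compound 1 to compound 3 (0.57 log units; beyond the scatter), with hydrogen in place of methyl, shows that even this small change at the end of the chain is enough to be read beyond the scatter. Of these three compounds, compound 3, with its isopentyloxy group, has the highest number, while the cyclopentylmethoxy group of compound 2 and the extra methyl of compound 1 both go with lower numbers.

Nothing measured here explains why the number rises with this change. Also open, as far as these compounds go, is how a longer chain, or an amine on the chain, would compare at this place.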